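Series notes: 3,5-dimethoxyphenyl replacing 3-nitrophenyl

The source may report more compounds than this note shows. Statements on the series, on what has been measured and on what is new or still open speak of the compounds shown alone.

In a functional assay on SMMC-7721 cells (Homo sapiens) for cytotoxicity, read by MTT assay, with a stated time of 24 h (a lower number here means a stronger inhibitor, a higher number a weaker inhibitor), compound 1 `COc1cc(/C=C2\CN(S(=O)(=O)c3ccc(NC(C)=O)cc3)C/C(=C\c3cc(OC)c(OC)c(OC)c3)C2=O)cc(OC)c1OC` gives 3470 nM, compound 2 `COc1cc(/C=C2\CN(S(=O)(=O)c3ccc(NC(C)=O)cc3)C/C(=C\c3ccccc3F)C2=O)cc(OC)c1OC` gives 3920 nM and compound 3 `COc1cc(/C=C2\CN(S(=O)(=O)c3ccc(NC(C)=O)cc3)C/C(=C\c3cccc([N+](=O)[O-])c3)C2=O)cc(OC)c1OC` gives 1950 nM. Compound 3 thus stands within the scatter of both others, as seen in a 1.8-fold lower number from compound 1 to compound 3 (0.25 log units; within the scatter) and a 2.0-fold lower number from compound 2 to compound 3 (0.30 log units; within the scatter). Compound 4 `COc1cc(/C=C2\CN(S(=O)(=O)c3ccc(NC(C)=O)cc3)C/C(=C\c3cc(OC)c(OC)c(OC)c3)C2=O)cc(OC)c1` has 3,5-dimethoxyphenyl in place of 3-nitrophenyl on a double-bonded chain carbon bound to a double-bonded ring carbon. Three measured steps changed this same place, the third being a 1.1-fold higher number from compound 1 to compound 2 (0.05 log units; within the scatter), and all stayed within the scatter. Compound 1, with 3,4,5-trimethoxyphenyl there, is the nearest guide at 3470 nM, so no step beyond the scatter is expected in this assay. The estimated step, toward a higher number, is a 1.5-fold higher number from compound 3 to compound 4 (0.19 log units; within the scatter). For compound 4 the expected value is 3000 nM, with an estimated range of 1500 nM to 6000 nM.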

Compound 4, half-maximal inhibitory concentration: 4200 nM
The estimate for compound 4 lay 1.4-fold (0.15 log units) below the measured number; the range from low to high includes it.
By their numbers in this assay, from the lowest: compounds 3, 1, 2 and 4 (each within the scatter of the next, the first and the last beyond it).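

In this assay, this position gives its first step beyond the scatter, though a modest one, with 3,5-dimethoxyphenyl in place of 3-nitrophenyl (a 2.2-fold higher number from compound 3 to compound 4 (0.33 log units; beyond the scatter)). Replacing 2-fluorophenyl with 3,5-dimethoxyphenyl stays within the scatter (a 1.1-fold higher number from compound 2 to compound 4 (0.03 log units; within the scatter)), as does hydrogen in place of methoxy on an aromatic carbon (a 1.2-fold higher number from compound 1 to compound 4 (0.08 log units; within the scatter)). No available evidence bears on this result.

As far as these compounds go, how an amine or a carboxylic acid on this aromatic ring would read remains open. So does whether any group at this place gives more than a modest step.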